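The source may report more compounds than this note shows. Statements on the series, on what has been measured and on what is new or still open speak of the compounds shown alone.

Measured so far in a functional assay on SW-620 cells (Homo sapiens) for cytotoxicity, read by sulforhodamine B assay, with a stated time of 48 h; a lower number here means that less compound is tolerated, a higher number that more compound is tolerated:
compound 1 `ClCc1cccc(Cn2cnc3c(Cl)ncnc32)c1`: 8910 nM
compound 2 `ClCc1ccc(Cn2cnc3nc(Cl)nc(Cl)c32)cc1`: 64600 nM
compound 3 `ClCc1cccc(Cn2cnc3c(Cl)nc(Cl)nc32)c1`: 7760 nM

In this assay compound 2 gives the highest of the three numbers; its gaps to compound 1 and to compound 3 both lie beyond the scatter. Compound 2 and compound 3 have the same atoms joined differently; the difference between the two cores is not broken down here. Compound 3 and compound 1 differ in one place: hydrogen in place of chloro on an aromatic carbon The step that this change made is a 1.1-fold higher number from compound 3 to compound 1 (0.06 log units; within the scatter), so the number was left essentially unaltered.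

The same change leads from compound 2 to compound 4 `ClCc1ccc(Cn2cnc3ncnc(Cl)c32)cc1`, still unmeasured in this assay: hydrogen in place of chloro on an aromatic carbon The surroundings of the change are the same in both pairs, so it is the same change. The expectation is that it will again leave the number about where it stands, resting on the single prior observation a 1.1-fold higher number from compound 3 to compound 1 (0.06 log units; within the scatter). Compound 4 is thus expected to show a 1.1-fold higher number from compound 2 to compound 4 (0.03 log units; within the scatter). Among the compounds with values here, compound 4 is expected at about 70000 nM in this assay, with an estimated range from 30000 nM to 160000 nM; with only one earlier instance of the change, the range is kept wide.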

Compound 4, concentration lethal to 50% of the cells: 32400 nM
Beside the measured number, compound 4's estimate is 2.2-fold (0.33 log units) above it; the measured number falls inside the stated range.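

In this assay hydrogen in place of chloro on the aromatic carbon between two ring nitrogen atoms gives a 2.0-fold lower number from compound 2 to compound 4 (0.30 log units; within the scatter) and so leaves the number essentially where it stood on this second core as well. Set beside the earlier step, the change reads alike on both cores: the same change on two cores in this assay, a 1.1-fold higher number (0.06 log units; within the scatter) from compound 3 to compound 1 and a 2.0-fold lower number (0.30 log units; within the scatter) from compound 2 to compound 4, 2.3-fold (0.36 log units) apart, within the scatter of two such steps

Within this series, then, the change can be carried from the core of compound 3 to the core of compound 2 with no step beyond the scatter in this assay, but two pairs in a single assay show nothing about further cores or other cell lines, and they give no reason for the result.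

Still open, on these data alone, is whether a group other than hydrogen on that carbon, such as an amine or a methoxy group, would shift the number at all. Equally open, as far as these compounds go, is what would follow if a hydroxymethyl group or a longer chain took the place of the chloromethyl group.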